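Three Tolerated Amides and a Propanoyl Newcomer

The compounds below may be only part of what the source reports. "The series", "measured", "known", "first", "only" and "open" are said of these compounds alone.

The measured compounds:
Compound 1, `CSCC(=O)N1CCN(c2nc(=O)c3cc(C(F)(F)F)cc([N+](=O)[O-])c3s2)CC1`, gives > 125000 nM.
Compound 2, `CC(=O)N1CCN(c2nc(=O)c3cc(C(F)(F)F)cc([N+](=O)[O-])c3s2)CC1`, gives > 125000 nM.
Compound 3, `O=C(C1CC1)N1CCN(c2nc(=O)c3cc(C(F)(F)F)cc([N+](=O)[O-])c3s2)CC1`, gives > 125000 nM.

All three share one core and differ only in the group on the carbonyl carbon bound to the amide-type nitrogen in a ring. In an ADME assay on Vero cells (Chlorocebus sabaeus) for cytotoxicity, read by MTT assay, with a stated time of 72 h (a higher number here means that more compound is tolerated, a lower number that less compound is tolerated), compound 1 reaches a limit of the assay rather than a number. In this assay compound 2 likewise stops at a limit. Compound 3 also sits at a limit in this assay, so its exact tolerance is not known; it is simply at least as well tolerated as the assay can show, and the limit of > 125000 nM in this assay, at which 3 of the 3 values shown sit, marks where all three rest.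

Compound 4, `CCC(=O)N1CCN(c2nc(=O)c3cc(C(F)(F)F)cc([N+](=O)[O-])c3s2)CC1`, has not yet been measured. Its difference from compound 3 is ethyl in place of cyclopropyl on a carbonyl carbon.

The measured steps give little guidance: a step that the two limits leave unreadable from compound 1 to compound 2, a step that the two limits leave unreadable from compound 1 to compound 3 and a step that the two limits leave unreadable from compound 2 to compound 3 are all hidden by the limits. None of the changes at this carbonyl carbon has pulled a compound below the limit, and the step to compound 4 is of the same small kind. The step is therefore expected to be a step that the limit leaves unreadable from compound 3 to compound 4, most likely again ending at the limit. Compound 4 is expected to give 150000 nM in this assay, with a range from 80000 nM to 300000 nM.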

Compound 4, half-maximal cytotoxic concentration: > 125000 nM
Compound 4: a limit, no number (the forecaster's own chance of this, stated with the estimate: 85%); the middle value lies beyond the limit too.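

In this assay compound 4 gives > 125000 nM, which is a limit and not a number. Among the compounds shown here, no step among compound 1, compound 2, compound 3 and compound 4 can be read, and they share one mark: the limit of > 125000 nM in this assay, at which 4 of the 4 values shown sit. The compounds shown leave open how their tolerances truly compare, and whether any change on this carbonyl carbon alters tolerance.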